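Compound 2 to compound 4: 3-cyanophenyl for 4-cyanophenyl

This account rests on a few compounds, and the source may have more. Where it says the series, first, only, none or still open, it means among the compounds named here.

In a functional assay on DU-145 cells (Homo sapiens) for antiproliferative activity, read by MTT assay, with a stated time of 72 h (a higher number here means a weaker inhibitor, a lower number a stronger inhibitor), compound 1 `COc1cc2c(Nc3ccc(C#N)cc3)ncnc2cc1OCCCN(C)Cc1ccccc1` reads > 100000 nM as a limit of the assay and not a number. Compound 2 `COc1cc2c(Nc3ccc(C#N)cc3)ncnc2cc1OCCCN1CCCCC1` gives 24400 nM and compound 3 `COc1cc2c(Nc3ccc(C#N)cc3)ncnc2cc1OCCCN1CCC(CO)CC1` gives 53200 nM in the same read-out, which leaves compound 2 with the lower of the two actual numbers and compound 3 as its nearest neighbour.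

The change from compound 2 to compound 4 `COc1cc2c(Nc3cccc(C#N)c3)ncnc2cc1OCCCN1CCCCC1` is 3-cyanophenyl in place of 4-cyanophenyl on a nitrogen on an aromatic ring and the two have the same atoms, joined differently. Here 3-cyanophenyl stands in place of 4-cyanophenyl on a nitrogen on an aromatic ring.

Going by the values given here, no measured step touches this group. All of them alter the amine at the end of the saturated chain. The closest guides to size are a 2.2-fold higher number from compound 2 to compound 3 (0.34 log units; beyond the scatter) and an at least 4.0-fold lower number from compound 1 to compound 2 (0.61 log units; beyond the scatter) but the second of these rests on the limit, the limit of > 100000 nM in this assay, at which 1 of the 3 values shown sits, and neither gives a direction for the new change. As far as these compounds go, with no direction supported, a 1.0-fold higher number from compound 2 to compound 4 (0.01 log units; within the scatter) is the expected step, with no shift beyond the scatter favoured, although a modest move either way remains open. Compound 4 is estimated at 25000 nM in this assay with an expected range of 9000 nM to 70000 nM as the likely span.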

Compound 4, half-maximal inhibitory concentration: 29100 nM
Compound 4: the middle estimate sits 1.2-fold (0.07 log units) below what was measured; the range from low to high includes it.
By their numbers in this assay, from the lowest: compounds 2, 4 and 3 (each within the scatter of the next, the first and the last beyond it). At a limit, above all of these: compound 1.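

Going by these compounds alone, this is the first read on the aryl group on the nitrogen, as every earlier step altered the amine at the end of the saturated chain. With the piperidin-1-yl chain end held fixed, this assay gives a 1.2-fold higher number from compound 2 to compound 4 (0.08 log units; within the scatter), so this single pair does not separate 3-cyanophenyl from 4-cyanophenyl, whereas the hydroxymethyl change at the other end of the molecule gives a 2.2-fold higher number from compound 2 to compound 3 (0.34 log units; beyond the scatter). Nothing measured alongside these compounds bears on this result.

As far as these compounds go, the pair speaks only for the nitrile and only for the piperidin-1-yl chain end, so it remains open whether the same swap would read alike with 4-(hydroxymethyl)piperidin-1-yl or benzyl(methyl)amino at the end of the chain. Also open, from the compounds shown here alone, is how the aryl group would respond to a different group in place of the nitrile, such as a chlorine atom, a methoxy group or a carboxylic acid, or to a plain phenyl ring, and whether any such change would move the series away from the range of compound 4 at 29100 nM.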